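The source may hold more compounds than are shown below. What is called first, only, known or untested is meant among the compounds shown, and "the series" means these compounds.

Values in a functional assay on brain (Rattus norvegicus, strain Wistar) for inhibition; a higher number here means a weaker inhibitor, a lower number a stronger inhibitor
- compound 1 `Cc1[nH]c(=O)n(C2CCCCC2)c1-c1ccc(OCCC(C)C)cc1` gives 7200 nM
- compound 2 `CCCCCCCCCCOc1ccc(-c2c(C)[nH]c(=O)n2C2CCCCC2)cc1` gives 10500 nM

Compound 2 at 10500 nM lies within the scatter of compound 1 at 7200 nM and the two cannot be told apart. Compound 3 `CCCCCCCCCCCCOc1ccc(-c2c(C)[nH]c(=O)n2C2CCCCC2)cc1` is not yet measured. It differs from compound 2 by ethyl in place of hydrogen on a saturated chain carbon, ten or more bonds along the chain from an oxygen on an aromatic ring and so carries ethyl in place of hydrogen on a saturated chain carbon, ten or more bonds along the chain from an oxygen on an aromatic ring.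

The step of a 1.5-fold higher number from compound 1 to compound 2 (0.16 log units; within the scatter) is the only measured one that bears on this change. It came with octyl in place of isopropyl on a saturated chain carbon, two bonds along the chain from an oxygen on an aromatic ring. Among the measured compounds shown here, a single step is thin support, and no measurement yet covers a change this far along the chain. Even so, no step beyond the scatter is expected in this assay and no direction is favoured. The expected step is a 1.0-fold higher number from compound 2 to compound 3 (0.02 log units; within the scatter) as a working estimate. In this assay the estimated value for compound 3 is 11000 nM (expected range 5000 nM to 25000 nM).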

Compound 3, half-maximal inhibitory concentration: 52400 nM
The estimate for compound 3 lay 4.8-fold (0.68 log units) below the measured number, outside the stated range (above it).
By their numbers in this assay, from the lowest: compounds 1 and 2 (each within the scatter of the next); then compound 3.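

Notes on the chain in this assay: ethyl in place of hydrogen on a saturated chain carbon, ten or more bonds along the chain from an oxygen on an aromatic ring, gives the first step in this series beyond the scatter (a 5.0-fold higher number from compound 2 to compound 3 (0.70 log units; beyond the scatter)), whereas octyl in place of isopropyl stayed within it (a 1.5-fold higher number from compound 1 to compound 2 (0.16 log units; within the scatter)). Decyl in place of isopropyl also lands beyond the scatter (a 7.3-fold higher number from compound 1 to compound 3 (0.86 log units; beyond the scatter)), so compound 3 is the weakest inhibitor of the three, and the flat reading suggested by the first pair does not extend to this chain length. This is one rise at the far end of the chain, not yet a trend, and no measurement offered here accounts for it.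

On these data alone, whether the number climbs further with a longer chain, or settles at the level of compound 3, remains open. Also open, as far as these compounds go, is whether an amine or a carboxylic acid at the chain end, at this same distance from the oxygen on the aromatic ring, would follow the ethyl step or depart from it.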